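The source may hold more compounds than are shown below. What is called first, only, known or untested is meant among the compounds shown, and "the series" means these compounds.

Working notes on a short homocysteine-derived series tested in an assay on isolated protein for inhibition of betaine--homocysteine S-methyltransferase 1 (Homo sapiens), tested at 20 uM; a higher number here means more inhibition at the concentration tested (going by the name of the read-out), a lower number less inhibition. Compound 1 `NC(CCSCCCC(=O)O)C(=O)O` gives 20.1% in this assay. Compound 2 `NC(CCS(=O)(=O)CCCCC(=O)O)C(=O)O` gives 28.8% in this assay; the gap between compound 1 and compound 2 lies within the scatter, so the two stand level. Compound 3 `NC(CCSCCSCC(=O)O)C(=O)O` is not yet measured. It differs from compound 1 in one place: (carboxymethyl)sulfanyl in place of carboxymethyl on a saturated chain carbon, two bonds along the chain from a sulfur. Within the data shown here, no measured step of this kind is available, and compound 2 shows only that a longer, oxidised chain stays within the scatter of compound 1. For compound 3 a small step in this assay of a number 3.9 percentage points higher from compound 1 to compound 3 (within the scatter) is expected, not beyond the scatter in either direction. Compound 3 is estimated at 24%, with a range from 10% to 40%.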

Compound 3, a percentage reported as inhibition, at one concentration (the size of the read-out at that concentration, not a potency): 100%
The estimate for compound 3 lay 76 percentage points below the measured number, and the stated range ends below it.
By their numbers in this assay, from the lowest: compounds 1 and 2 (each within the scatter of the next); then compound 3.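

In this assay, among these compounds, replacing carboxymethyl with (carboxymethyl)sulfanyl on a saturated chain carbon, two bonds along the chain from a sulfur, gives a number 79.9 percentage points higher from compound 1 to compound 3 (beyond the scatter) and thus the first step beyond the scatter. This position therefore responds strongly to a single change, which compounds 1 and 2 could not show. Nothing measured here accounts for the size of this step.

As far as these compounds go, it remains open whether an ether oxygen or a methylene group in place of the added sulfur would retain this inhibition. From the compounds shown here alone, the effect of a longer chain between that sulfur and the carboxylic acid is also open.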